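A Ring-Bearing Group Replaces a Dimethylaminoethyl Chain

The source may report more compounds than this note shows. Statements on the series, on what has been measured and on what is new or still open speak of the compounds shown alone.

Compound 1 `CNC(=O)Nc1ccc(-c2nc(N3CC4CCC(C3)O4)c3cnn(CCN(C)C)c3n2)cc1`: 400 nM
Compound 2 `O=C(Nc1ccccc1)Nc1ccc(-c2nc(N3CC4CCC(C3)O4)c3cnn(C4CCC5(CC4)OCCO5)c3n2)cc1`: 4 nM

In a functional assay on LNCaP cells (Homo sapiens) for cytotoxicity (on this read-out lower numbers stand for stronger inhibition and higher numbers for weaker inhibition), compound 1 stands at 400 nM, the higher of the two numbers and so the weaker inhibitor, while compound 2 gives 4 nM. These two compounds differ in more than one place, so their gap cannot be pinned on any single change. Compound 3 `CNC(=O)Nc1ccc(-c2nc(N3CC4CCC(C3)O4)c3cnn(C4CCC5(CC4)OCCCO5)c3n2)cc1` keeps the rest of compound 1 and changes one group on an aromatic nitrogen: a group of 11 heavy atoms (9 carbon, 2 oxygen; one six-membered non-aromatic ring of carbon only, one six-membered non-aromatic ring with 2 hetero atoms) in place of a group of 5 heavy atoms (4 carbon, 1 nitrogen; no ring), on an aromatic nitrogen. The expectation of a gain rests on compound 2 at 4 nM, which also carries a two-ring group on that nitrogen. Its other difference from compound 3 leaves the size of any gain uncertain. In this assay, the expected step is a 16-fold lower number from compound 1 to compound 3 (1.20 log units; beyond the scatter), toward stronger inhibition and beyond the scatter. For compound 3, the estimated value is 25 nM, within an expected range of 5 nM to 120 nM.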

Compound 3, half-maximal inhibitory concentration: 8 nM
Compound 3: middle estimate off by 3.1-fold (0.49 log units), on the high side, and the stated range covers the measured number.
By their numbers in this assay, from the lowest: compounds 2 and 3 (each within the scatter of the next); then compound 1.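

In this assay, replacing the 2-(dimethylamino)ethyl chain on the aromatic nitrogen with the two-ring group, while the rest of compound 1 stays the same, gives a 50-fold lower number from compound 1 to compound 3 (1.70 log units; beyond the scatter). The gap between compound 1 and compound 2 could not be tied to one place, but this step shows that a change at this nitrogen alone can move the number by a large amount. Nothing measured here says what lies behind the step.

As far as these compounds go, it remains open which part of the entering group matters: a plain cyclohexyl group or a piperidine ring on the same nitrogen would help to separate the carbon ring from the oxygen-bearing ring. Compound 2 and compound 3 differ in more than one place, so their closeness cannot be assigned to either difference.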